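Extending the biaryl arm with a methoxystyryl group

A few compounds are considered here, and "the series" means these few. Any claim that something is new, unique, unknown or untested is made for them only; others in the source may bear on it.

Measured compounds and values:
- Compound 1, `CCCCCCCCS(=O)(=O)Nc1cc(-c2ccccc2Cl)ccc1C(=O)O`: 26900 nM
- Compound 2, `CCCCCCCCS(=O)(=O)Nc1cc(-c2ccccc2O)ccc1C(=O)O`: 63100 nM
- Compound 3, `CCCCCCCCS(=O)(=O)Nc1cc(-c2ccc(O)cc2)ccc1C(=O)O`: 64800 nM

In an assay on mitochondria (strain BALB/c) for inhibition of glycerol-3-phosphate acyltransferase 1, mitochondrial (Mus musculus), read by scintillation counting, with a stated time of 10 min (a higher number here means a weaker inhibitor, a lower number a stronger inhibitor), compound 3 gives the highest number of the three, though its value sits within the scatter of compound 2, as a 1.0-fold higher number from compound 2 to compound 3 (0.01 log units; within the scatter) shows; both stand apart from compound 1, see a 2.4-fold higher number from compound 1 to compound 3 (0.38 log units; beyond the scatter) and a 2.3-fold higher number from compound 1 to compound 2 (0.37 log units; beyond the scatter).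

Compound 4 is `CCCCCCCCS(=O)(=O)Nc1cc(/C=C/c2ccc(OC)cc2)ccc1C(=O)O`. The change from compound 3 is 2-(4-methoxyphenyl)ethenyl in place of 4-hydroxyphenyl on an aromatic carbon. For the measured compounds named here, no measured step covers this change: the steps so far only swap a chloro for a hydroxy or move the hydroxy around the ring, and each of those was modest at most. The new group has no hydrogen-bond donor, like the chloro-bearing compound 1, and a longer reach than any group tried. A modest drop in the number toward compound 1 is therefore expected, but with wide uncertainty, giving an estimated 2.2-fold lower number from compound 3 to compound 4 (0.33 log units; beyond the scatter). Compound 4 is expected at 30000 nM, between 8000 nM and 120000 nM.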

Compound 4, half-maximal inhibitory concentration: 38700 nM
The estimate for compound 4 lay 1.3-fold (0.11 log units) below the measured number; measured number inside the range.
By their numbers in this assay, from the lowest: compounds 1, 4, 2 and 3 (each within the scatter of the next, the first and the last beyond it).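

On this aromatic carbon, para to a carboxy group, the position accepts a longer arm carrying a double bond outside the aromatic rings, with no clear loss or gain in this assay: the readings are a 1.7-fold lower number from compound 3 to compound 4 (0.22 log units; within the scatter) and a 1.6-fold lower number from compound 2 to compound 4 (0.21 log units; within the scatter) and also a 1.4-fold higher number from compound 1 to compound 4 (0.16 log units; within the scatter). Compound 4 therefore lies within the scatter of all three earlier compounds, even though compound 1 and compound 3 differ beyond it, so it cannot show whether this new group behaves more like the 2-chlorophenyl or the 4-hydroxyphenyl group. No measurement here offers an explanation for this result.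

The roles of the double bond and the methoxy group remain unseparated. A 2-(4-hydroxyphenyl)ethenyl group or a saturated 2-(4-methoxyphenyl)ethyl group would test each part, and an amine on the far ring would probe a different kind of substituent.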